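A few compounds are considered here, and "the series" means these few. Any claim that something is new, unique, unknown or untested is made for them only; others in the source may bear on it.

Compound 1 `COc1ccccc1Oc1ccc2c(NCCCNCc3ccco3)ccnc2c1` gives 6500 nM in an ADME assay on HepG2 cells (Homo sapiens) for cytotoxicity, read by luminescence, CellTiter-Glo and ATP content, with a stated time of 72 h; a higher number here means that more compound is needed for the effect, a lower number that less compound is needed. Compound 2 `COc1cccc(CNCCCNc2ccnc3cc(-c4ccc(C(F)(F)F)cc4)ccc23)c1O` gives 2210 nM in this assay. Compound 3 `COc1ccc(F)cc1CNCCCNc1ccnc2cc(CCc3ccccc3)ccc12` gives 4240 nM in this assay.

Compound 3 stands second highest of the three numbers, and its value lies within the usual scatter of both compound 1 and compound 2. Compound 4 `COc1ccc(F)cc1CNCCCNc1ccnc2cc(Cc3ccccc3)ccc12` has not yet been measured in this assay. It differs from compound 3 in a single place: phenyl in place of benzyl on a saturated chain carbon bound to an aromatic carbon. Within the data shown here, no pair of measured compounds shows the effect of such a change, and the three measured values sit close together. The expected step in this assay from a 1.1-fold lower number from compound 3 to compound 4 (0.03 log units; within the scatter) is small, in neither direction beyond the scatter. Compound 4 is estimated at 4000 nM, in the range 1800 nM to 9000 nM.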

Compound 4, half-maximal effective concentration: 7990 nM
Compound 4: middle estimate off by 2.0-fold (0.30 log units), on the low side; low and high end bracket the measured number.
By their numbers in this assay, from the lowest: compounds 2, 3, 1 and 4 (each within the scatter of the next, the first and the last beyond it).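

In this assay, phenyl in place of benzyl on a saturated chain carbon bound to an aromatic carbon gives a 1.9-fold higher number from compound 3 to compound 4 (0.28 log units; within the scatter). Among these compounds, this is the first direct reading of a change at this position, and it shows that the change from phenethyl to benzyl stays within the usual scatter here. Nothing measured on these compounds offers an explanation for this step. From the compounds shown here alone, whether a longer chain or an amine at this place would move the number beyond the scatter remains open. So does whether the same small step would hold with other groups on the shared core.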